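Propyl on the Second Ring Nitrogen of a Dipropyl Series

The compounds below may be only part of what the source reports. "The series", "measured", "known", "first", "only" and "open" are said of these compounds alone.

Compound 1 `Cn1c(=O)[nH]c2cc[nH]c2c1=O`: 2900 nM
Compound 2 `CCCn1c(=O)[nH]c2cc[nH]c2c1=O`: 1700 nM

The two measured compounds share one core and differ only in the chain on one aromatic nitrogen. In an assay for binding affinity to adenosine receptor A1 (Rattus norvegicus), in the presence of a further agent that is not named here (on this read-out higher numbers stand for weaker inhibition and lower numbers for stronger inhibition), compound 1 gives 2900 nM, and compound 2 gives 1700 nM. The single measured step, a 1.7-fold lower number from compound 1 to compound 2 (0.23 log units; within the scatter), is too small to count as a real difference, so on the numbers shown compound 2 has the lower value but cannot be called stronger than compound 1.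

Compound 3 `CCCn1c(=O)c2[nH]ccc2n(CCC)c1=O` is not yet measured. It differs from compound 2 by propyl in place of hydrogen on an aromatic nitrogen. Within the data shown here, no measured step changes a hydrogen on an aromatic nitrogen into a chain; the one step known, from a shorter to a longer chain on an already substituted nitrogen, stayed within the scatter. That step therefore gives only weak guidance here, and the change in compound 3 is of a different kind.

The expectation for compound 3 is a modest move in this assay, estimated at a 1.4-fold lower number from compound 2 to compound 3 (0.15 log units; within the scatter), with wide uncertainty. Compound 3 is expected to give about 1200 nM, within a range from 300 nM to 5000 nM.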

Compound 3, inhibition constant: 440 nM
Compound 3: middle estimate off by 2.7-fold (0.44 log units), on the high side, and the stated range covers the measured number.
By their numbers in this assay, from the lowest: compound 3; then compounds 2 and 1 (each within the scatter of the next).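

Replacing hydrogen with propyl on this aromatic nitrogen of the six-membered ring has a clearer effect in this assay than the chain change seen earlier: the new change gives a 3.9-fold lower number from compound 2 to compound 3 (0.59 log units; beyond the scatter), whereas the earlier step, a 1.7-fold lower number from compound 1 to compound 2 (0.23 log units; within the scatter), could not be told apart from repeat-to-repeat variation. So this position, which carries hydrogen in compound 2, is one where adding a chain can shift the number by a real, though modest, amount, and compound 3 stands beyond the scatter of compound 2. Nothing measured here explains the shift, so the result records what changed but gives no reason for it.

A single substituent on this nitrogen cannot show whether propyl itself matters, and a methyl group, a longer chain such as butyl, or a chain ending in an amine or a carboxylic acid could each give a different answer. The compounds also leave open what would follow from replacing the hydrogen on the remaining ring nitrogen of compound 3 , and whether the same change would hold in any other assay.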